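The source may hold more compounds than are shown below. What is called first, only, known or untested is meant among the compounds shown, and "the series" means these compounds.

Measured compounds:
compound 1 `Clc1ccc(-c2noc(-c3cc4cc(Cl)ccc4[nH]3)n2)cc1`
compound 2 `COc1ccc(-c2noc(-c3cc4ccccc4[nH]3)n2)cc1`

In a functional assay on MCF7 cells (Homo sapiens) for antiproliferative activity, read by WST assay, with a stated time of 72 h (on this read-out lower numbers stand for stronger inhibition and higher numbers for weaker inhibition), compound 1 gives > 50000 nM, a limit of the assay rather than a number. In this assay compound 2 gives > 50000 nM, again a limit and not a number. Compound 2 thus stands at the limit of > 50000 nM in this assay, at which 2 of the 2 values shown sit; both values shown sit there, and nothing separates the two compounds. For the measured compounds named here, no pair of measured compounds differs in only one place, so no measured step exists. Compound 3 `COc1ccc(-c2noc(-c3cc4cc(Cl)ccc4[nH]3)n2)cc1` differs from compound 2 by chloro in place of hydrogen on an aromatic carbon, the chloro entering meta to a fused ring and para to a fused ring. Compound 1 already carries this chloro and in this assay gives > 50000 nM, also a limit. The step that the limit leaves unreadable from compound 2 to compound 3 is expected to be none beyond the scatter. Compound 3 is expected to give 60000 nM in this assay, between 25000 nM and 150000 nM, most probably reported again only as a limit.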

Compound 3, half-maximal inhibitory concentration: > 50000 nM
Compound 3 was reported as a limit (the forecaster's own chance of this, stated with the estimate: 85%); the middle value is on the limit's open side.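

No new step can be read in this assay, as compound 3, like compound 1 and compound 2, is reported only as a limit: the limit of > 50000 nM in this assay, at which 3 of the 3 values shown sit.

The compounds shown leave open whether chloro in place of hydrogen, or methoxy in place of chloro, changes the activity at all.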